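A few compounds are considered here, and "the series" means these few. Any claim that something is new, unique, unknown or untested is made for them only; others in the source may bear on it.

Measured so far in a functional assay for inhibition, with Rattus norvegicus as the target; on this read-out lower numbers stand for an effect already at smaller amounts and higher numbers for an effect only at larger amounts of compound:
Compound 1 `CCCCCCCCCCCCCCC1(C(=O)OCCCC)CO1` gives 10 uM.
Compound 2 `CCCCCCC1(C(=O)OC)CO1` gives 20 uM.

Of these two numbers compound 1 has the lowest, and compound 2 lies within the scatter of it, so no order can be read between them. Compound 3 `CCCCCCCCCCCCCCC1(C(=O)OC)CO1` differs from compound 1 by hydrogen in place of propyl on a saturated chain carbon bound to an oxygen next to a carbonyl group. Among the measured compounds shown here, no pair of measured compounds shows this change on its own, so there is no measured step to lean on. The step of a 1.2-fold higher number from compound 1 to compound 3 (0.08 log units; within the scatter) is expected to stay within the scatter, in no clear direction. Compound 3 is therefore estimated at 12 uM, in the range 5 uM to 30 uM.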

Compound 3, minimum effective concentration: 0.1 uM
For compound 3 the middle estimate is 120-fold (2.08 log units) above the measured one, and the stated range ends above it.
By their numbers in this assay, from the lowest: compound 3; then compounds 1 and 2 (each within the scatter of the next).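

Cutting the ester from butoxycarbonyl to methoxycarbonyl while the long chain stays gives a 100-fold lower number from compound 1 to compound 3 (2.00 log units; beyond the scatter) in this assay and so shows that this end of the molecule matters greatly, which compounds 1 and 2 could not show, since they differ in more than one place. Nothing available here explains so large a step. Still open, as far as these compounds go, is whether an ethyl or propyl ester would fall near compound 1 or compound 3, and whether a carboxylic acid or an amide in this place would keep the effect.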